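A few compounds are considered here, and "the series" means these few. Any claim that something is new, unique, unknown or untested is made for them only; others in the source may bear on it.

Compound 1 `COc1ccc(NC(=O)c2cc(Oc3ccc(/C=C/c4ccncc4)cc3)ccn2)cc1`: > 100000 nM
Compound 2 `COc1ccc(CNC(=O)c2cc(Oc3ccc(/C=C/c4ccncc4)cc3)ccn2)cc1`: > 100000 nM

Both measured compounds share one core and differ only at the amide-type nitrogen, where compound 2 carries 4-methoxybenzyl in place of 4-methoxyphenyl. In a functional assay on HepG2 cells (Homo sapiens) for antiproliferative activity, read by CCK-8 assay, with a stated time of 48 h (on this read-out higher numbers stand for weaker inhibition and lower numbers for stronger inhibition), compound 1 gives > 100000 nM, which is a limit of the assay rather than a number. In this assay compound 2 gives > 100000 nM, again a limit. The step that the two limits leave unreadable from compound 1 to compound 2 therefore cannot be read, because the limit of > 100000 nM in this assay, at which 2 of the 2 values shown sit, means neither value is a real number. Compound 2 thus stands at the edge of what this assay can report, alongside compound 1, and nothing separates the two.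

Compound 3 `O=C(c1cc(Oc2ccc(/C=C/c3ccncc3)cc2)ccn1)N1CCCC1` has not been measured. It differs from compound 2 as follows: pyrrolidin-1-yl in place of (4-methoxybenzyl)amino on a carbonyl carbon. No measured step bears directly on this change; the only step shown, a step that the two limits leave unreadable from compound 1 to compound 2, is unreadable, so no size or direction can be borrowed from it. With both measured compounds at the limit, compound 3 is expected to stay there as well, an expected step of a number no higher from compound 2 to compound 3 (the limit leaves the size open). The estimate for compound 3 in this assay is 100000 nM, with a range from 30000 nM to 300000 nM, and a strong chance that only a limit is reported once more.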

Compound 3, half-maximal inhibitory concentration: 41600 nM
The estimate for compound 3 lay 2.4-fold (0.38 log units) above the measured number; the range from low to high includes it.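

At the carbonyl carbon, the group attached can bring the read-out off its limit. In this assay, pyrrolidin-1-yl gives an at least 2.4-fold lower number from compound 2 to compound 3 (0.38 log units; beyond the scatter), and the same group in place of (4-methoxyphenyl)amino gives an at least 2.4-fold lower number from compound 1 to compound 3 (0.38 log units; beyond the scatter). The first readable number among these compounds therefore comes with a five-membered non-aromatic ring that has no aromatic carbon ring and no amide hydrogen, but these differences arrive together, so the data cannot assign the change to any one of them. The true size of both steps remains unknown because one end of each is not a number: the limit of > 100000 nM in this assay, at which 2 of the 3 values shown sit.

The step between compound 1 and compound 2 still cannot be read, so the compounds shown say nothing about how the aromatic amides compare with each other. Going by these compounds, it also remains open whether another group without the amide hydrogen, such as dimethylamino, piperidin-1-yl or morpholin-4-yl, would lower the number further, match compound 3 or return to the limit.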